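The source may report more compounds than this note shows. Statements on the series, on what has been measured and on what is new or still open speak of the compounds shown alone.

Compound 3 `Cc1cc(C(=O)N2CCCCc3ccccc32)ccc1CNC(=O)N1C[C@H](O)C[C@H]1C(=O)N(C)C` stands lowest of the three numbers recorded here. In a functional assay on HEK293 cells for agonist activity at Vasopressin V2 receptor (Homo sapiens), read by a luciferase reporter and cAMP accumulation (a lower number here means that less compound is needed, a higher number that more compound is needed for the effect), compound 3 gives 2.3 nM. Compound 1 `Cc1cc(C(=O)N2CCCCc3ccccc32)ccc1CNC(=O)NCC(=O)OC(C)C` gives 140 nM in this assay, and compound 2 `Cc1cc(C(=O)N2CCCCc3ccccc32)ccc1CNC(=O)N1CCC[C@H]1C(=O)O` gives 680 nM in this assay. The steps among these three all sit on the same carbonyl carbon: a 4.9-fold higher number from compound 1 to compound 2 (0.69 log units; beyond the scatter), a 61-fold lower number from compound 1 to compound 3 (1.78 log units; beyond the scatter) and a 300-fold lower number from compound 2 to compound 3 (2.47 log units; beyond the scatter). The two steps that lead to compound 3 are large, and both bring in the 2-(dimethylcarbamoyl)-4-hydroxypyrrolidin-1-yl group as a whole.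

Compound 4 `Cc1cc(C(=O)N2CCCCc3ccccc32)ccc1CNC(=O)N1CC(=O)C[C@H]1C(=O)N(C)C` is compound 3 with 2-(dimethylcarbamoyl)-4-oxopyrrolidin-1-yl in place of 2-(dimethylcarbamoyl)-4-hydroxypyrrolidin-1-yl on a carbonyl carbon. Among the measured compounds shown here, none of the measured steps isolates the hydroxyl of that ring, since each swaps the entire substituent on the carbonyl carbon, so they show only that this position carries the bulk of the differences seen, not what the loss of the single hydrogen-bond donor does. As compound 4 keeps the dimethylcarbamoyl pyrrolidine that compound 3 also carries, a step in this assay of the size a 3.0-fold higher number from compound 3 to compound 4 (0.48 log units; beyond the scatter) is expected, a modest rise rather than a return toward compound 1 or compound 2. Compound 4 is therefore estimated at 7 nM in this assay, with a range from 2 nM to 30 nM.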

Compound 4, half-maximal effective concentration: 27 nM
The estimate for compound 4 lay 3.9-fold (0.59 log units) below the measured number; low and high end bracket the measured number.
By their numbers in this assay, from the lowest: compound 3; then compound 4; then compound 1; then compound 2.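

Among the compounds shown here, with the dimethylcarbamoyl pyrrolidine kept, the exchange of 2-(dimethylcarbamoyl)-4-hydroxypyrrolidin-1-yl for 2-(dimethylcarbamoyl)-4-oxopyrrolidin-1-yl gives a 12-fold higher number from compound 3 to compound 4 (1.07 log units; beyond the scatter) in this assay and is the first step here to show that the hydroxyl counts on its own at this carbonyl carbon, where the earlier steps could only speak for the substituent as a whole. The oxo ring still keeps part of the advantage of that substituent, with a 25-fold lower number from compound 2 to compound 4 (1.40 log units; beyond the scatter) against the 2-carboxypyrrolidin-1-yl group and a 5.2-fold lower number from compound 1 to compound 4 (0.71 log units; beyond the scatter) against the ((isopropoxycarbonyl)methyl)amino group, so only part of the gain of compound 3 goes with the hydroxyl. Nothing available on these compounds accounts for the size of the step from hydroxyl to oxo.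

The compounds shown leave open how a methoxy group, an amine or a fluorine in place of the hydroxyl would stand, so the hydroxyl cannot yet be told apart from the oxygen it carries. Also open, on these data alone, are the other configuration of the hydroxyl carbon and whether a carboxylic acid in place of the dimethylcarbamoyl group would be tolerated with the hydroxyl present.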